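Replacing 3-fluorophenyl with 4-hydroxyphenyl in compound 1

The source may hold more compounds than are shown below. What is called first, only, known or untested is meant among the compounds shown, and "the series" means these compounds.

Compound 1 `CN(C)C(=O)c1cc2cnc(Nc3ccc(NC(=O)C4(C(=O)Nc5cccc(F)c5)CC4)cc3)nc2n1C1CCCC1`: 98.8%
Compound 2 `CN(C)C(=O)c1cc2cnc(Nc3ccc(NC(=O)C4(C(=O)Nc5ccc(F)cc5)CC4)cc3F)nc2n1C1CCCC1`: 53%

These two compounds were tested in a functional assay on NCI-H460 cells (Homo sapiens) for inhibition, read by CCK-8 assay, with a stated time of 72 h, tested at 10 uM; a higher number here means more inhibition of growth at the concentration tested, a lower number less inhibition of growth. Compound 1 stands highest of the two at 98.8%, and the gap down to compound 2 at 53% lies beyond the usual scatter of such measurements.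

The next compound to be tested is compound 3 `CN(C)C(=O)c1cc2cnc(Nc3ccc(NC(=O)C4(C(=O)Nc5ccc(O)cc5)CC4)cc3)nc2n1C1CCCC1`. It keeps the rest of compound 1 and changes one group: 4-hydroxyphenyl in place of 3-fluorophenyl on an amide-type nitrogen. In words, 4-hydroxyphenyl stands in place of 3-fluorophenyl on an amide-type nitrogen.

Among the compounds with values here, no measured pair shows this change alone, so the data give no direct size for it. Compound 1 at 98.8% has little room left to rise, and compound 2 at 53% shows that a close relative can read much lower. A moderate fall, beyond the scatter, is therefore expected, with a number 23.8 percentage points lower from compound 1 to compound 3 (beyond the scatter) as the estimated step. Compound 3 is estimated to give 75%, within an expected range of 45% to 98%.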

Compound 3, percent growth inhibition at one concentration: 104%
Compound 3: middle estimate off by 29 percentage points, on the low side; the measured number lies above the stated range.
By their numbers in this assay, from the lowest: compound 2; then compounds 1 and 3 (each within the scatter of the next).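

In this assay, within the data shown here, putting 4-hydroxyphenyl in place of 3-fluorophenyl on an amide-type nitrogen gives a number 5.2 percentage points higher from compound 1 to compound 3 (within the scatter), the first reading of a change at this one place. It shows that, at the single concentration tested, this position accepts a phenyl group carrying a hydrogen-bond donor and acceptor in place of one with neither, with no difference that can be told from the scatter. No measurement here explains why the two groups read alike in cell growth.

Going by these compounds, compound 1 and compound 3 both read close to full inhibition at one concentration, and the swap changes both the substituent and its place on the ring, so any difference in strength at lower concentrations and the separate roles of the substituent and its place remain unknown. Also open, on these data alone, is whether an amine, a carboxylic acid or a methoxy group in place of the hydroxyl on this phenyl ring would read like compound 3, and compound 2, which differs from compound 1 in more than one place, cannot settle this.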